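This account rests on a few compounds, and the source may have more. Where it says the series, first, only, none or still open, it means among the compounds named here.

Working notes on the oxime and benzylidene series.

Two cores are present. Compound 1 `CC(C)=CCC/C(C)=C/CC/C(C)=C/CC[C@@H]1[C@@]2(C)CC/C(=N\OCc3cn(-c4cccc(O)c4)nn3)C(C)(C)[C@@H]2CC[C@@]1(C)O` and compound 2 `CC(C)=CCC/C(C)=C/CC/C(C)=C/CC[C@@H]1[C@@]2(C)CC/C(=N\OCc3cn(-c4ccc(F)c(Cl)c4)nn3)C(C)(C)[C@@H]2CC[C@@]1(C)O` share one core; compound 3 `CC(C)=CCC/C(C)=C/CC/C(C)=C/CC[C@@H]1[C@@]2(C)C/C(=C\c3ccc(OCc4cn(-c5cccc(O)c5)nn4)cc3)C(=O)C(C)(C)[C@@H]2CC[C@@]1(C)O` and compound 4 `CC(C)=CCC/C(C)=C/CC/C(C)=C/CC[C@@H]1[C@@]2(C)C/C(=C\c3ccc(OCc4cn(-c5ccc(F)c(Cl)c5)nn4)cc3)C(=O)C(C)(C)[C@@H]2CC[C@@]1(C)O` share the other. How the two cores differ is not broken down here.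

In a functional assay on A549 cells (Homo sapiens) for cytotoxicity, read by MTT assay, with a stated time of 48 h (a higher number here means a weaker inhibitor, a lower number a stronger inhibitor), compound 1 gives 12800 nM. In this assay compound 2 gives 21400 nM. The change between them is 3-chloro-4-fluorophenyl in place of 3-hydroxyphenyl on an aromatic nitrogen and it gives a 1.7-fold higher number from compound 1 to compound 2 (0.22 log units; within the scatter). In this assay compound 3 gives 110000 nM, the highest number of the three measured compounds and beyond the scatter from both compound 1 and compound 2.

The same change, (3-chloro-4-fluorophenyl in place of 3-hydroxyphenyl on an aromatic nitrogen), occurs a second time between compound 3 and compound 4; the surroundings of the place are described in the same words in both cases. Because the first occurrence gave a 1.7-fold higher number from compound 1 to compound 2 (0.22 log units; within the scatter), the step from compound 3 to compound 4 is expected to be a 1.5-fold higher number from compound 3 to compound 4 (0.16 log units; within the scatter). Compound 4 is therefore estimated at 160000 nM in this assay, with the range 70000 nM to 400000 nM expected.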

Compound 4, half-maximal inhibitory concentration: 46600 nM
Beside the measured number, compound 4's estimate is 3.4-fold (0.54 log units) above it, and the stated range ends above it.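

In this assay, 3-chloro-4-fluorophenyl in place of 3-hydroxyphenyl gives a 2.4-fold lower number from compound 3 to compound 4 (0.37 log units; beyond the scatter), so the step measured on the first core does not carry over to the second in size or direction: the same change on two cores in this assay, a 1.7-fold higher number (0.22 log units; within the scatter) from compound 1 to compound 2 and a 2.4-fold lower number (0.37 log units; beyond the scatter) from compound 3 to compound 4, 3.9-fold (0.60 log units) apart, beyond the scatter of two such steps For these two pairs, then, the step read on the core of compound 1 and compound 2 is a poor guide to the same change on the core of compound 3 and compound 4. This does not show which difference between the cores lies behind the gap, and a single pair on each core cannot say whether other groups on that aromatic nitrogen would diverge in the same way.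

The compounds shown leave open whether chlorine alone or fluorine alone would give the step seen on either core. Also open, as far as these compounds go, is how each core would respond to an unsubstituted phenyl, a phenyl bearing an amine or a carboxylic acid, or a longer alkyl chain at the same place.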